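This account rests on a few compounds, and the source may have more. Where it says the series, first, only, none or still open, it means among the compounds named here.

Working notes on the series. Compound 1 `CC(C)(C)OC(=O)NCCC[C@@H]1N=C2C[C@@H]3C[C@@H](C3(C)C)[C@]2(C)OC1=O` gives in a functional assay on EL4 cells (Mus musculus) for antiproliferative activity, read by sulforhodamine B assay, with a stated time of 48 h (on this read-out higher numbers stand for weaker inhibition and lower numbers for stronger inhibition), a value of 4100 nM. Compound 2 `C[C@H]1N=C2C[C@H]3C[C@H](C3(C)C)[C@@]2(C)OC1=O` gives in this assay 27000 nM, and compound 3 `CC1(C)[C@@H]2CC3=N[C@@H](CCC(=O)O)C(=O)O[C@@]3(C)[C@H]1C2` gives 36000 nM. Compound 1 thus shows the lowest number of the three, and its gaps to compound 2 and to compound 3 both lie beyond the usual scatter; compound 2 and compound 3 fall within the scatter of each other, so no order between those two is drawn.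

Compound 4 `CC(C)(C)OC(=O)NCCC[C@H]1N=C2C[C@H]3C[C@H](C3(C)C)[C@@]2(C)OC1=O` has not yet been measured in this assay. It differs from compound 1 as follows: the two compounds have the same atoms and bonds and differ only in configuration as drawn: 4 of 4 stereo elements differ (all stereocentres are inverted: mirror images); a stereocentre at a saturated ring carbon is drawn S in compound 1 and R in compound 4; a stereocentre at a saturated ring carbon is drawn S in compound 1 and R in compound 4; a stereocentre at a saturated ring carbon is drawn S in compound 1 and R in compound 4; a stereocentre at a saturated ring carbon is drawn S in compound 1 and R in compound 4. Among the compounds with values here, no pair of measured compounds differs in configuration alone, so the set holds no measured step of this kind to lean on, and nothing measured here says whether the mirror image keeps the number of compound 1. The working assumption is a step toward a higher number, likely beyond the scatter, with the range kept wide enough to cover a step in either direction. The step from compound 1 to compound 4 expected here is a 2.2-fold higher number from compound 1 to compound 4 (0.34 log units; beyond the scatter). Compound 4 is accordingly estimated at 9000 nM, within a range from 2500 nM to 40000 nM.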

Compound 4, half-maximal inhibitory concentration: 48000 nM
Compound 4: the middle estimate sits 5.3-fold (0.73 log units) below what was measured; the measured number lies above the stated range.
By their numbers in this assay, from the lowest: compound 1; then compounds 2, 3 and 4 (each within the scatter of the next).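

In this assay the series now holds a measured step of configuration alone, and it is large: a 12-fold higher number from compound 1 to compound 4 (1.07 log units; beyond the scatter). With no group entering or leaving, the whole of this step goes with the inversion, because nothing else separates the pair: the fact that compounds 1 and 4 differ only in the configuration as drawn. Within the data shown here, the side chain and the shared core therefore do not set the number on their own, since the lower number of compound 1 is tied to its configuration as drawn and is not kept by its mirror image, a dependence that the earlier compounds could not show.

As far as these compounds go, all four stereocentres are inverted together, so it stays open whether the step rests on one of them, on some of them or on all four, and a compound with a single inverted stereocentre would be needed to separate these cases. From the compounds shown here alone, it also stays open whether a step of this size holds for other chain ends, such as a free amine or an amide in place of the present carbamate, or for a longer chain.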